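Working notes on compounds 1 to 4

A few compounds are considered here, and "the series" means these few. Any claim that something is new, unique, unknown or untested is made for them only; others in the source may bear on it.

Measured so far:
- Compound 1 `COCC/C(=C(/c1ccc(/C=C/C(=O)O)cc1)c1ccc2[nH]ncc2c1)c1ccccc1`: in a functional assay on MCF7 cells (Homo sapiens) for cytotoxicity, read by CellTiter-Glo, with a stated time of 5 days (a lower number here means a stronger inhibitor, a higher number a weaker inhibitor), compound 1 gives 63 nM
- Compound 2 `CC(C)/C(=C(/c1ccc(/C=C/C(=O)O)cc1)c1ccc2[nH]ncc2c1)c1ccccc1`: in this assay compound 2 gives 4 nM
- Compound 3 `CC/C(=C(/c1ccc(/C=C/C(=O)O)cc1)c1ccc2[nH]ncc2n1)c1ccccc1`: in this assay compound 3 gives 33 nM

Compound 3 stands second highest of the three numbers; its value and that of compound 1 lie within the scatter of each other, while compound 2 sits well below it, beyond the scatter.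

Compound 4 `CC/C(=C(/c1ccc(/C=C/C(=O)O)cc1)c1ccc2[nH]ncc2c1C)c1ccccc1` is not yet measured. It differs from compound 3 in one place: a group of 10 heavy atoms (8 carbon, 2 nitrogen; one five-membered aromatic ring with 2 hetero atoms, one six-membered aromatic ring of carbon only) in place of a group of 9 heavy atoms (6 carbon, 3 nitrogen; one five-membered aromatic ring with 2 hetero atoms, one six-membered aromatic ring with 1 hetero atom), on a double-bonded chain carbon bound to an aromatic carbon and a double-bonded chain carbon.

Among the measured compounds shown here, the only measured step, a 16-fold lower number from compound 1 to compound 2 (1.20 log units; beyond the scatter), concerns a substituent on a different carbon of the chain and does not bear on the ring change from compound 3 to compound 4. For the measured compounds named here, no pair among compounds 1 to 3 isolates the change in question, so no direction can be read from the data; a step within the scatter, or a modest one either way, is the reasonable expectation.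

Compound 4 is therefore estimated at 25 nM in this assay, with a range of 6 nM to 100 nM, which means an expected step of a 1.3-fold lower number from compound 3 to compound 4 (0.12 log units; within the scatter).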

Compound 4, half-maximal inhibitory concentration: 50 nM
The estimate for compound 4 lay 2.0-fold (0.30 log units) below the measured number; measured number inside the range.
By their numbers in this assay, from the lowest: compound 2; then compounds 3, 4 and 1 (each within the scatter of the next).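

In this assay, putting 4-methyl-1H-indazol-5-yl in place of the group on this double-bonded chain carbon gives a 1.5-fold higher number from compound 3 to compound 4 (0.18 log units; within the scatter), so the two compounds cannot be told apart. This position therefore accepts a six-membered aromatic ring of carbon only carrying a methyl, with one hydrogen-bond acceptor fewer in the group, and the number stays in the same band as that of compound 3. No measurement at hand offers an explanation for this result.

The entering group differs from the leaving one both in the ring nitrogen and in the methyl, and the compounds shown contain no pair that separates the two. Also open, as far as these compounds go, is what a chlorine atom or a methoxy group in place of that methyl would give in this assay.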